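Isopropyl for propargyl on a sulfonamide nitrogen

The source may report more compounds than this note shows. Statements on the series, on what has been measured and on what is new or still open speak of the compounds shown alone.

Compound 1, `Cc1ccccc1N(C)S(=O)(=O)c1cc(Cl)ccc1Cl`, gives in an ADME assay on A549 cells (Homo sapiens) for cytotoxicity, read by MTT assay (a lower number here means that less compound is tolerated, a higher number that more compound is tolerated), a value of > 5000 nM, which is a limit of the assay and not a number.
Compound 2, `C#CCN(c1ccccc1C)S(=O)(=O)c1cc(Cl)ccc1Cl`, gives in this assay a value of > 5000 nM, likewise a limit of the assay.

Compound 2 therefore stands at the limit of > 5000 nM in this assay, at which 2 of the 2 values shown sit, with no number of its own. Within the data shown here, the only measured step, a step that the two limits leave unreadable from compound 1 to compound 2, has a limit at each end, so its size is unknown.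

Compound 3, `Cc1ccccc1N(C(C)C)S(=O)(=O)c1cc(Cl)ccc1Cl`, differs from compound 2 by isopropyl in place of propargyl on a sulfonamide nitrogen. Among the measured compounds shown here, no measured step has a readable size that could bear on this change, and the two compounds with data both sit at the limit. The expected step is a step that the limit leaves unreadable from compound 2 to compound 3 in this assay, that is, none beyond the scatter, and compound 3 is most likely to be reported as a limit as well. Compound 3 is estimated at 8000 nM, with a range from 3000 nM to 30000 nM.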

Compound 3, half-maximal cytotoxic concentration: > 5000 nM
Compound 3: only a limit was reported (the forecaster's own chance of this, stated with the estimate: 85%); the middle value is on the limit's open side.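

In this assay compound 3 gives > 5000 nM, a limit of the assay and not a number, so neither step to it, from compound 1 or from compound 2, can be read. The compounds shown leave open whether the group on the sulfonamide nitrogen affects cytotoxicity at all.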